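The source may hold more compounds than are shown below. What is called first, only, known or untested is meant among the compounds shown, and "the series" means these compounds.

Measured compounds:
compound 1 `COc1ccc(-c2cc(C(=O)/C=C/c3ccccc3)nc3cc(-c4ccccc4)nn23)cc1OC` gives 18600 nM
compound 2 `COc1cc(-c2cc(C(=O)/C=C/c3ccc(Cl)cc3)nc3cc(-c4ccccc4)nn23)cc(OC)c1OC` gives 23800 nM

The two measured compounds were tested in a functional assay on A549 cells (Homo sapiens) for antiproliferative activity, read by MTT assay, with a stated time of 24 h; on this read-out higher numbers stand for weaker inhibition and lower numbers for stronger inhibition. Compound 1 in this assay gives 18600 nM, and compound 2 gives 23800 nM; these two numbers lie within the scatter of each other, so nothing separates compound 2 from compound 1 on the numbers shown.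

The step considered here leads from compound 2 to compound 3 `COc1cc(-c2cc(C(=O)/C=C/c3ccccc3)nc3cc(-c4ccccc4)nn23)cc(OC)c1OC`, which is not yet measured. The change is hydrogen in place of chloro on an aromatic carbon, para to a large group, within the 2-(4-chlorophenyl)ethenyl part that becomes 2-phenylethenyl. Among the measured compounds shown here, no measured pair shows this change on the shared core. Compound 1, which already carries the 2-phenylethenyl group, gives 18600 nM, a number within the scatter of compound 2, so the step of a 1.2-fold lower number from compound 2 to compound 3 (0.08 log units; within the scatter) is expected to be small, with no direction beyond the scatter. Compound 3 is therefore estimated at 20000 nM, with a range from 8000 nM to 50000 nM.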

Compound 3, half-maximal inhibitory concentration: 18000 nM
Compound 3: the middle estimate sits 1.1-fold (0.05 log units) above what was measured; measured number inside the range.
By their numbers in this assay, from the lowest: compounds 3, 1 and 2 (each within the scatter of the next).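

In this assay, among the compounds shown here, compound 2 and compound 3 form the first pair that differs only at this position, and the step reads a 1.3-fold lower number from compound 2 to compound 3 (0.12 log units; within the scatter), so on these numbers chloro and hydrogen on this aromatic carbon, para to a large group, cannot be told apart. The second pair adds that methoxy in place of hydrogen on an aromatic carbon also leaves the number within the scatter, with the step of a 1.0-fold lower number from compound 1 to compound 3 (0.01 log units; within the scatter). Nothing measured here offers a reason for either result.

From the compounds shown here alone, whether an amine, a carboxylic acid or a nitrile at this position would give a step beyond the scatter remains open. The carbonyl, the ethenyl link and the shared core stay the same throughout, so the compounds shown say nothing about changes there.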